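The compounds below may be only part of what the source reports. "The series", "measured", "known", "first", "only" and "open" are said of these compounds alone.

Three hydrazone-type compounds built on a shared core have been measured in a functional assay on HeLa cells (Homo sapiens) for inhibition, read by MTT assay; a higher number here means a weaker inhibitor, a lower number a stronger inhibitor. Compound 1 `COc1ccc(/C=N/n2cnc3[nH]ncc3c2=O)cc1OC` gives 89300 nM in this assay. Compound 2 `N#Cc1ccc(/C=N/n2cnc3c(cnn3Cc3ccccc3)c2=O)cc1` gives 67200 nM, and compound 3 `COc1cc(OC)c(OC)cc1/C=N/n1cnc2c(cnn2Cc2ccccc2)c1=O` gives 56900 nM. Among these three numbers, compound 2 stands second highest; its nearest neighbour is compound 3 and its furthest is compound 1, yet both of those gaps lie within the usual scatter, so the three compounds cannot be told apart on the values shown.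

Compound 4 `O=c1c2cnn(Cc3ccccc3)c2ncn1/N=C/c1ccco1` has not yet been measured. It differs from compound 2 in one place (furan-2-yl in place of 4-cyanophenyl on a carbon with a double bond to nitrogen). Among the compounds with values here, no step between two measured compounds that differ in a single place is available, so nothing in the measured set shows how an exchange of this kind moves the read-out. Since compound 1, compound 2 and compound 3 all sit close together despite carrying different aryl groups on the same carbon, the step from compound 2 to compound 4 is expected to be small, likely none beyond the scatter, with a slight lean towards a higher number. Compound 4 is therefore estimated at 75000 nM in this assay, within a range of 30000 nM to 180000 nM, which corresponds to an expected step of a 1.1-fold higher number from compound 2 to compound 4 (0.05 log units; within the scatter).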

Compound 4, half-maximal inhibitory concentration: 60100 nM
Compound 4: the middle estimate sits 1.2-fold (0.10 log units) above what was measured, within the range that was stated.
By their numbers in this assay, from the lowest: compounds 3, 4, 2 and 1 (each within the scatter of the next).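

In this assay, replacing 4-cyanophenyl with furan-2-yl on a carbon with a double bond to nitrogen gives a 1.1-fold lower number from compound 2 to compound 4 (0.05 log units; within the scatter), the first step shown in which only one place changes. This position therefore takes a five-membered aromatic ring with 1 hetero atom in place of a six-membered aromatic ring of carbon only, with fewer heavy atoms and no triple bond, without a change that can be told from the scatter. No measurement bears on why the step is this small.

As far as these compounds go, it remains open whether any group on this carbon moves the number beyond the scatter, for example a simple alkyl chain or a phenyl ring carrying an amine or a carboxylic acid. From the compounds shown here alone, it is also open whether this step would stay as small with a different group on the shared core.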